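Moving the chlorine around the anilide ring of a chromone

The source may report more compounds than this note shows. Statements on the series, on what has been measured and on what is new or still open speak of the compounds shown alone.

Three compounds share one core and were tested in a functional assay on A549 cells (Homo sapiens) for inhibition, read by MTT assay, with a stated time of 48 h; on this read-out higher numbers stand for weaker inhibition and lower numbers for stronger inhibition. Compound 1 `COc1ccc2c(=O)c(/C=C/C(=O)Nc3ccccc3Cl)coc2c1` gives 29900 nM. Compound 2 `COc1ccc2c(=O)c(/C=C/C(=O)Nc3ccccc3C)coc2c1` gives 23400 nM, and compound 3 `Cc1ccc(CNC(=O)/C=C/c2coc3cc(O)ccc3c2=O)cc1` gives 17400 nM. Compound 1 therefore has the highest of the three numbers, but both of the others lie within the scatter of it, so no order among them can be read. Going by the values given here, the one single-point step among them, a 1.3-fold lower number from compound 1 to compound 2 (0.11 log units; within the scatter), swaps one group for another at the same position and changes nothing beyond the scatter.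

Compound 4 `COc1ccc2c(=O)c(/C=C/C(=O)Nc3ccc(Cl)cc3)coc2c1` keeps every atom of compound 1 and only rearranges them: 4-chlorophenyl in place of 2-chlorophenyl on an amide-type nitrogen. Cut one bond further out, the same difference reads (2-chlorophenyl)amino to (4-chlorophenyl)amino. Among the compounds with values here, no measured step moves a group from one position to another, so the only guide is the step from compound 1 to compound 2, which stayed within the scatter. The expectation for compound 4 is therefore a step of a 1.2-fold lower number from compound 1 to compound 4 (0.08 log units; within the scatter) in this assay, which is no step beyond the scatter. Compound 4 is expected to give about 25000 nM, between 9000 nM and 70000 nM.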

Compound 4, half-maximal inhibitory concentration: > 100000 nM
Compound 4: no number, only a limit; the forecaster's own chance of this, stated with the estimate: 10%; middle value at least 4.0-fold (0.60 log units) from the limit.
By their numbers in this assay, from the lowest: compounds 3, 2 and 1 (each within the scatter of the next). At a limit, above all of these: compound 4.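

Compound 4's result is a limit of the assay and not a number: the limit of > 100000 nM in this assay, at which 1 of the 4 values shown sits.

Even so, it shows that where the chlorine sits matters in this assay: putting 4-chlorophenyl in place of 2-chlorophenyl on the amide-type nitrogen gives an at least 3.3-fold higher number from compound 1 to compound 4 (0.52 log units; beyond the scatter), a step beyond the scatter. The comparison with the methyl compound points the same way, with an at least 4.2-fold higher number from compound 2 to compound 4 (0.63 log units; beyond the scatter), whereas swapping chloro for methyl in the same place gave only a 1.3-fold lower number from compound 1 to compound 2 (0.11 log units; within the scatter) and stayed within the scatter.

Going by these compounds, whether another group, such as an amine or a carboxylic acid in place of the chlorine of compound 4, would bring the number back down stays open. On these data alone, the true size of these steps also stays open, as compound 4 has no number.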